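The source may report more compounds than this note shows. Statements on the series, on what has been measured and on what is new or still open speak of the compounds shown alone.

In an ADME assay on Vero cells (Chlorocebus sabaeus) for cytotoxicity, read by fluorescence and resazurin assay, with a stated time of 3 days (a higher number here means that more compound is tolerated, a lower number that less compound is tolerated), compound 1 `COc1ccc(N/N=C2\C(=O)N(Cc3cn(C[C@H]4O[C@@H]5OC(C)(C)O[C@@H]5[C@H]4O)nn3)c3ccccc32)cc1` gives 74500 nM, and compound 2 `CC1(C)O[C@H]2O[C@H](Cn3cc(CN4C(=O)/C(=N\Nc5ccc(C#N)cc5)c5ccccc54)nn3)[C@H](O)[C@H]2O1` gives 105000 nM. Within the data shown here, these two numbers lie within the scatter of each other, so compound 2 stands level with the only other measured member of the series.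

The next entry is compound 3 `CC1(C)O[C@H]2O[C@H](Cn3cc(CN4C(=O)/C(=N\Nc5ccc(F)cc5)c5ccccc54)nn3)[C@H](O)[C@H]2O1`, which keeps the rest of compound 2 and differs in one group: fluoro in place of cyano on an aromatic carbon. In words, this is fluoro in place of cyano on an aromatic carbon, para to a large group.

Among the measured compounds shown here, only one measured step bears on this, an exchange of groups on the same aromatic carbon, methoxy to cyano: a 1.4-fold higher number from compound 1 to compound 2 (0.15 log units; within the scatter). That step stays within the scatter. For the measured compounds named here, it is a single step, though, and no fluoro compound has been measured yet, so the basis is thin. No step beyond the scatter is expected in this assay, in either direction. The expected step is a 1.2-fold lower number from compound 2 to compound 3 (0.07 log units; within the scatter). For compound 3 the estimated value is 90000 nM, with an expected range of 45000 nM to 180000 nM.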

Compound 3, half-maximal cytotoxic concentration: 83800 nM
The estimate for compound 3 lay 1.1-fold (0.03 log units) above the measured number, and the stated range covers the measured number.
By their numbers in this assay, from the lowest: compounds 1, 3 and 2 (each within the scatter of the next).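

In this assay, the aromatic carbon para to a large group has now carried methoxy, cyano and fluoro, and the new entry adds two steps: a 1.3-fold lower number from compound 2 to compound 3 (0.10 log units; within the scatter) and a 1.1-fold higher number from compound 1 to compound 3 (0.05 log units; within the scatter). Neither step leaves the scatter, and with the earlier methoxy-to-cyano step, all three pairs among these groups now stand level. This holds even for the change from cyano, with its 2 heavy atoms and 1 hydrogen-bond acceptor, to fluoro, with 1 heavy atom and no hydrogen-bond acceptor, so the tolerated concentration separates none of these three compounds, and no measured data on any property of these groups accompany the result.

Still open is whether an amine, a carboxylic acid or a longer alkyl chain on this same aromatic carbon would give a step beyond the scatter, since the three groups shown cover only a narrow set of replacements. Also open, going by these compounds, is whether this level picture would persist with a change elsewhere on the shared core, as all three compounds keep the rest of the structure unchanged.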